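Growing the Hydroxyalkyl Group: Hydroxyethyl to Hydroxycyclohexyl

The source may hold more compounds than are shown below. What is called first, only, known or untested is meant among the compounds shown, and "the series" means these compounds.

Compound 1 `OCCc1cn(CCNc2nonc2/C(=N/O)Nc2ccc(F)c(Br)c2)nn1`: in an assay on isolated protein for inhibition of Indoleamine 2,3-dioxygenase 2 (Homo sapiens) (a higher number here means a weaker inhibitor, a lower number a stronger inhibitor), compound 1 gives 1170 nM.
Compound 2 `OCCCc1cn(CCNc2nonc2/C(=N/O)Nc2ccc(F)c(Br)c2)nn1`: compound 2 gives 958 nM.
Compound 3 `CC(O)c1cn(CCNc2nonc2/C(=N/O)Nc2ccc(F)c(Br)c2)nn1`: compound 3 gives 362 nM.

Compound 3 gives the lowest number of the three; the steps of a 3.2-fold lower number from compound 1 to compound 3 (0.51 log units; beyond the scatter) and a 2.6-fold lower number from compound 2 to compound 3 (0.42 log units; beyond the scatter) both lie beyond the scatter, so compound 3 is the strongest inhibitor here. Compound 4 `O/N=C(\Nc1ccc(F)c(Br)c1)c1nonc1NCCn1cc(C2(O)CCCCC2)nn1` differs from it by 1-hydroxycyclohexyl in place of 1-hydroxyethyl on an aromatic carbon. The step of a 1.2-fold lower number from compound 1 to compound 2 (0.09 log units; within the scatter) shows that lengthening the chain changed little, while the two steps into compound 3 show that placing the hydroxyl on the carbon attached to the aromatic carbon helped modestly. Among the measured compounds shown here, compound 4 keeps that placement; no measured step tests the added ring, so the expected step of a 1.1-fold lower number from compound 3 to compound 4 (0.05 log units; within the scatter) is about none beyond the scatter. Compound 4 is estimated at 320 nM, between 110 nM and 950 nM.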

Compound 4, half-maximal inhibitory concentration: 865 nM
Estimate against measurement, compound 4: 2.7-fold (0.43 log units) below, within the range that was stated.
By their numbers in this assay, from the lowest: compound 3; then compounds 4, 2 and 1 (each within the scatter of the next).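

Placing the hydroxyl on the carbon attached to the aromatic ring is not enough on its own: in this assay, 1-hydroxycyclohexyl in place of 1-hydroxyethyl gives a 2.4-fold higher number from compound 3 to compound 4 (0.38 log units; beyond the scatter). Compound 4 thus loses the modest advantage of compound 3 and stands level with the open-chain alcohols, with a 1.1-fold lower number from compound 2 to compound 4 (0.04 log units; within the scatter) and a 1.4-fold lower number from compound 1 to compound 4 (0.13 log units; within the scatter). No evidence is available on what lies behind this result.

Still open, from the compounds shown here alone, is how a smaller ring, such as 1-hydroxycyclopropyl, or a 2-hydroxypropan-2-yl group would fare here. Also open, going by these compounds, is whether an amine could replace the hydroxyl.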